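Chalcone-type series: aryl ketone exchange at the carbonyl

This account rests on a few compounds, and the source may have more. Where it says the series, first, only, none or still open, it means among the compounds named here.

Measured compounds in a functional assay on HCT-116 cells (Homo sapiens) for inhibition, read by sulforhodamine B assay, with a stated time of 72 h; a lower number here means a stronger inhibitor, a higher number a weaker inhibitor:
- compound 1 `COc1ccc(C(=O)/C=C/c2cn(-c3ccccc3)nc2-c2ccsc2)c(OC)c1OC`: 5800 nM
- compound 2 `O=C(/C=C/c1cn(-c2ccccc2)nc1-c1cccnc1)c1cc[nH]c1`: 7400 nM

Compound 2 carries the higher of the two numbers, but its nearest neighbour, compound 1, sits within the usual scatter of it, so the two values are read as indistinguishable on the evidence at hand. Among the measured compounds shown here, compound 1 and compound 2 differ in two places at once, so no single-change step can be drawn between them; only their two values stand side by side.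

Compound 3 `COc1ccc(C(=O)/C=C/c2cn(-c3ccccc3)nc2-c2cccnc2)c(OC)c1` is not yet measured. It follows from compound 2 by one change: 2,4-dimethoxyphenyl in place of 1H-pyrrol-3-yl on a carbonyl carbon. Compound 1, which also carries a methoxy-substituted phenyl on the carbonyl carbon, gives 5800 nM, a value within the scatter of compound 2, so the exchange of the aryl ketone in this series has not so far shown a step beyond the scatter.

For compound 3 the number in this assay is expected to change little, with at most a small move toward a lower value, a step from compound 2 of a 1.5-fold lower number from compound 2 to compound 3 (0.17 log units; within the scatter). The estimate for compound 3 is 5000 nM, with a range from 1800 nM to 14000 nM.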

Compound 3, half-maximal inhibitory concentration: 1300 nM
The estimate for compound 3 lay 3.8-fold (0.59 log units) above the measured number, outside the stated range (below it).
By their numbers in this assay, from the lowest: compound 3; then compounds 1 and 2 (each within the scatter of the next).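

On the carbonyl carbon, 2,4-dimethoxyphenyl in place of 1H-pyrrol-3-yl gives a 5.7-fold lower number from compound 2 to compound 3 (0.76 log units; beyond the scatter) in this assay, a step beyond the scatter. This shows that the group on the carbonyl carbon can move the number in this series, which compound 1 and compound 2 could not show, since they differ in two places at once and their values lie within the scatter. No measurement at hand bears on what lies behind the step.

The change replaces a five-membered aromatic ring carrying a hydrogen-bond donor with a six-membered aromatic ring of carbon only carrying two methoxy groups, so the compounds shown do not separate the ring exchange from the methoxy groups. A plain phenyl or a phenyl with a single methoxy on the carbonyl carbon would divide the step between these parts, and the compounds shown do not say whether the same exchange holds with another group in place of the pyridine of compound 3.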